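Series notes: the step from compound 3 to compound 4

The compounds below may be only part of what the source reports. "The series", "measured", "known", "first", "only" and "open" are said of these compounds alone.

Measured so far:
compound 1 `Cc1ccc(NC(=O)NC(=O)c2ccc(OCc3ccccc3)cc2)cc1-c1nc2ccccc2[nH]1`, 16400 nM
compound 2 `Cc1ccc(NC(=O)NC(=O)c2ccc(OCc3ccc(Cl)c(Cl)c3)cc2)cc1-c1nc2ccccc2[nH]1`, 1030 nM
compound 3 `Cc1ccc(NC(=O)NC(=O)c2ccc(OCc3ccc(F)cc3)cc2)cc1-c1nc2ccccc2[nH]1`, 980 nM

All three numbers come from a functional assay on HT-29 cells (Homo sapiens) for inhibition, read by MTT assay, with a stated time of 48 h; a higher number here means a weaker inhibitor, a lower number a stronger inhibitor. Compound 3 carries the lowest number shown, but its nearest neighbour is compound 2 with a 1.1-fold lower number from compound 2 to compound 3 (0.02 log units; within the scatter), so these two cannot be told apart; only compound 1 stands clearly apart, with a 17-fold lower number from compound 1 to compound 3 (1.22 log units; beyond the scatter) and a 16-fold lower number from compound 1 to compound 2 (1.20 log units; beyond the scatter).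

Compound 4 `O=C(NC(=O)c1ccc(OCc2ccc(F)cc2)cc1)Nc1ccc(Cl)c(-c2nc3ccccc3[nH]2)c1` is not yet measured. It differs from compound 3 by chloro in place of methyl on an aromatic carbon. Both measured steps that pass the scatter alter the group on the saturated chain carbon bound to an oxygen on an aromatic ring, on the other side of the shared core; neither touches the position changed here. Among the measured compounds shown here, no measured step therefore bears on the change from compound 3 to compound 4, and nothing supports a shift in either direction. The expectation is a step of a 1.0-fold higher number from compound 3 to compound 4 (0.01 log units; within the scatter) that stays within the scatter. Compound 4 is estimated in this assay at 1000 nM, with a range from 300 nM to 3500 nM.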

Compound 4, half-maximal inhibitory concentration: 730 nM
For compound 4 the middle estimate is 1.4-fold (0.14 log units) above the measured one, and the stated range covers the measured number.
By their numbers in this assay, from the lowest: compounds 4, 3 and 2 (each within the scatter of the next); then compound 1.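

The only step shown at this position is chloro in place of methyl on an aromatic carbon, ortho to a 1H-benzimidazol-2-yl group and para to a large group; with the 4-fluorophenyl end held constant, it gives a 1.3-fold lower number from compound 3 to compound 4 (0.13 log units; within the scatter) in this assay. Compounds 3 and 4 therefore cannot be told apart, and this exchange of one heavy atom for another leaves the reading unresolved from the scatter. Nothing shown offers an explanation of this result.

Methyl and chloro are the only groups shown at this position, so it remains open whether an amine or a carboxylic acid there would give a clearly different number. From the compounds shown here alone, it also remains open whether chloro behaves the same way when paired with the unsubstituted phenyl of compound 1 or the 3,4-dichlorophenyl of compound 2.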